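The compounds below may be only part of what the source reports. "The series", "measured", "known", "first", "only" and "open" are said of these compounds alone.

Compound 1 `Cc1ccc(C(=O)N2CCCN2C(=O)c2ccc(N3C(=O)C4CC=CCC4C3=O)cc2)cc1C` gives < 35% in an assay on isolated protein for inhibition of metabotropic glutamate receptor 5 (Homo sapiens), tested at 10 uM (a higher number here means more inhibition at the concentration tested (going by the name of the read-out), a lower number less inhibition), a limit of the assay rather than a number. Compound 2 `COc1ccc(C(=O)COC(=O)c2ccc(N3C(=O)C4CC=CCC4C3=O)cc2)cc1` gives 39% in this assay. Compound 3 `Cc1ccc(CNC(=O)Nc2ccc(N3C(=O)C4CC=CCC4C3=O)cc2)cc1C` gives < 35% in this assay, which is again only a limit.

Compound 3 therefore stands at the floor of what the numbers show: its inhibition is known only as a limit, and it shares that position with compound 1, as the limit of < 35% in this assay, at which 2 of the 3 values shown sit, records. For the measured compounds named here, the only numerical value among the three, that of compound 2, sits close to the same limit, so the whole set lies in a narrow band at the weak end.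

Compound 4 `Cc1ccc(NCC(=O)Nc2ccc(N3C(=O)C4CC=CCC4C3=O)cc2)cc1C` has not yet been measured. It differs from compound 3 by ((3,4-dimethylphenyl)amino)methyl in place of (3,4-dimethylbenzyl)amino on a carbonyl carbon. With no measured step between any two of the compounds shown, the expected size of the step from compound 3 to compound 4 in this assay is none beyond the scatter, with compound 4 most likely reported at the limit as well. Compound 4 is estimated at 30% in this assay, between 15% and 45%, the expected change being a step that the limit leaves unreadable from compound 3 to compound 4.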

Compound 4, a percentage reported as inhibition, at one concentration (the size of the read-out at that concentration, not a potency): < 35%
Compound 4: no number, only a limit; the forecaster's own chance of this, stated with the estimate: 60%; the middle value is on the limit's open side.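

No step between compound 3 and compound 4 can be read, because both are reported only as limits: the limit of < 35% in this assay, at which 3 of the 4 values shown sit.

The compounds shown leave open whether ((3,4-dimethylphenyl)amino)methyl in place of (3,4-dimethylbenzyl)amino changes the read-out at all, and where either compound truly lies.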